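Swapping the pyridine for a methoxyphenyl on the sulfonamide

A few compounds are considered here, and "the series" means these few. Any claim that something is new, unique, unknown or untested is made for them only; others in the source may bear on it.

Measured compounds:
- compound 1, `Cc1ccc(-c2ccccc2S(=O)(=O)N2CCC(N3CCC(C)CC3)CC2)cc1`: 366 nM
- compound 2, `CC1CCN(C2CCN(S(=O)(=O)c3cccnc3)CC2)CC1`: 2400 nM
- compound 3, `CC1CCN(C2CCN(S(=O)(=O)c3cccc4cnccc34)CC2)CC1`: 225 nM

All three compounds share a core in which a sulfonyl group carries an aromatic ring on one side and a ring nitrogen on the other, and they were tested in a functional assay on DLD-1 cells (Homo sapiens) for antiproliferative activity, read by CellTiter-Glo, with a stated time of 72 h; a higher number here means a weaker inhibitor, a lower number a stronger inhibitor. Compound 2 stands at the highest number of the three, which means it is the weakest inhibitor here; compound 1 lies clearly below it, and compound 3 lies further below still, both gaps beyond the usual scatter. Compound 4, `COc1cccc(S(=O)(=O)N2CCC(N3CCC(C)CC3)CC2)c1`, has not been measured yet. It differs from compound 2 in one place: 3-methoxyphenyl in place of pyridin-3-yl on a sulfonyl sulfur. Both rings that gave lower numbers than compound 2, in compound 1 and compound 3, are larger carbon-rich aromatic systems, so the change to a carbon-only ring in compound 4 is expected to move the number downward by a moderate step, a 3.0-fold lower number from compound 2 to compound 4 (0.48 log units; beyond the scatter), though a result within the scatter of compound 2 cannot be ruled out. Compound 4 is therefore estimated at 800 nM in this assay, with a likely range from 250 nM to 2500 nM.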

Compound 4, half-maximal inhibitory concentration: > 5000 nM
Compound 4: only a limit was reported (the forecaster's own chance of this, stated with the estimate: 5%); middle value at least 6.2-fold (0.79 log units) from the limit.
By their numbers in this assay, from the lowest: compounds 3 and 1 (each within the scatter of the next); then compound 2. At a limit, above all of these: compound 4.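

On the sulfonyl sulfur, the aromatic ring can cost activity as well as gain it: in this assay, 3-methoxyphenyl in place of pyridin-3-yl gives an at least 2.0-fold higher number from compound 2 to compound 4 (0.31 log units; beyond the scatter). The result for compound 4 is a limit and not a number: the limit of > 5000 nM in this assay, at which 1 of the 4 values shown sits. This is the first single change shown at this position, and it shows that a carbon-only ring there does not by itself bring a lower number.

The change removes the ring nitrogen and adds a methoxy group in one move, and the compounds shown cannot separate these two parts: a plain phenyl ring, or a pyridin-3-yl ring carrying a methoxy group, would each hold only one of them. Going by these compounds, it also stays open how a different group on the carbon-only ring, such as an amine or a carboxylic acid, would read in this assay, and how far the true value of compound 4 lies beyond its limit.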